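The source may report more compounds than this note shows. Statements on the series, on what has been measured and on what is new or still open speak of the compounds shown alone.

Measured so far in a functional assay on MCF7 cells (Homo sapiens) for cytotoxicity, read by MTT assay, with a stated time of 72 h; on this read-out lower numbers stand for stronger inhibition and higher numbers for weaker inhibition:
compound 1 `COc1ncc(-c2ccc3nc(NC(=O)N(C)C)nn3c2)cc1NS(=O)(=O)c1ccc(F)cc1`: 1560 nM
compound 2 `COc1ncc(-c2ccc3nc(NC(=O)NCCN(C)C)nn3c2)cc1NS(=O)(=O)c1ccc(F)cc1`: 560 nM
compound 3 `CCCNC(=O)Nc1nc2ccc(-c3cnc(OC)c(NS(=O)(=O)c4ccc(F)cc4)c3)cn2n1`: 360 nM

Compound 3 stands at the low end of these numbers, clear of the top of the set with a 4.3-fold lower number from compound 1 to compound 3 (0.64 log units; beyond the scatter), while a 1.6-fold lower number from compound 2 to compound 3 (0.19 log units; within the scatter) shows no separation from its nearest neighbour.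

Next is compound 4 `COc1ncc(-c2ccc3nc(NC(=O)NCC(=O)N4CCOCC4)nn3c2)cc1NS(=O)(=O)c1ccc(F)cc1`. The difference is (morpholin-4-yl)carbonyl in place of ethyl on a saturated chain carbon bound to an amide-type nitrogen. For the measured compounds named here, no measured compound carries this group, so the steps give only indirect guidance. Going by the values given here, the closest precedent, methyl in place of dimethylamino on a saturated chain carbon, gave a 1.6-fold lower number from compound 2 to compound 3 (0.19 log units; within the scatter). Changes on a carbonyl carbon gave larger but still modest steps, a 2.8-fold lower number from compound 1 to compound 2 (0.44 log units; beyond the scatter) and a 4.3-fold lower number from compound 1 to compound 3 (0.64 log units; beyond the scatter). A small step in this assay is therefore expected, toward a higher number and close to the scatter. The expected step is a 1.7-fold higher number from compound 3 to compound 4 (0.22 log units; within the scatter). Compound 4 is estimated at 600 nM, with an expected range of 200 nM to 1800 nM.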

Compound 4, half-maximal inhibitory concentration: 630 nM
For compound 4 the middle estimate is 1.1-fold (0.02 log units) below the measured one, within the range that was stated.
By their numbers in this assay, from the lowest: compounds 3, 2 and 4 (each within the scatter of the next); then compound 1.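

On a saturated chain carbon bound to an amide-type nitrogen, (morpholin-4-yl)carbonyl brings a six-membered non-aromatic ring, yet the result in this assay stays within the scatter of both open-chain comparators, with a 1.8-fold higher number from compound 3 to compound 4 (0.24 log units; within the scatter) and a 1.1-fold higher number from compound 2 to compound 4 (0.05 log units; within the scatter). Read one bond further out on the carbonyl carbon, (((morpholin-4-yl)carbonyl)methyl)amino in place of dimethylamino gives a 2.5-fold lower number from compound 1 to compound 4 (0.39 log units; beyond the scatter), so all three replacements of dimethylamino at that carbon now lie beyond the scatter from compound 1, in the same direction. No measured evidence is available to explain this result.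

On these data alone, whether a carboxylic acid or a piperazine amide on that chain carbon would stay within the same scatter remains open. A primary amine there and a longer chain leading to the morpholine amide are equally untested in the compounds shown.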